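Swapping a Hydroxycyclohexyl Ether for a Benzyl Ether

This account rests on a few compounds, and the source may have more. Where it says the series, first, only, none or still open, it means among the compounds named here.

Measured so far in a functional assay on RS4-11 cells (Homo sapiens) for inhibition, read by CCK-8 assay, with a stated time of 48 h; a higher number here means a weaker inhibitor, a lower number a stronger inhibitor:
Compound 1, `O=[N+]([O-])c1ccc(NC(=S)NCCNS(=O)(=O)c2ccc(-c3ccccc3O[C@H]3CC[C@@H](O)CC3)s2)cc1`, gives 9400 nM.
Compound 2, `O=[N+]([O-])c1ccc(NC(=S)NCCNS(=O)(=O)c2ccc(-c3ccccc3OCc3ccccc3)s2)cc1`, gives 11300 nM.
Compound 3, `O=S(=O)(NCCNC(=S)Nc1cc(C(F)(F)F)cc(C(F)(F)F)c1)c1ccc(-c2ccccc2O[C@H]2CC[C@@H](O)CC2)s1`, gives 6300 nM.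

Compound 1 and compound 2 share one core and differ in a single place: benzyl in place of 4-hydroxycyclohexyl on an oxygen on an aromatic ring This exchange produced a 1.2-fold higher number from compound 1 to compound 2 (0.08 log units; within the scatter), so the two numbers cannot be told apart with confidence. Compound 3 is built on a different core; the difference between the two cores is not broken down here. Its value and those of compound 1 and compound 2 all lie within the usual scatter of one another, so no ordering among the three is claimed.

Compound 4, `O=S(=O)(NCCNC(=S)Nc1cc(C(F)(F)F)cc(C(F)(F)F)c1)c1ccc(-c2ccccc2OCc2ccccc2)s1`, has not yet been measured. It is related to compound 3 exactly as compound 2 is related to compound 1: benzyl in place of 4-hydroxycyclohexyl on an oxygen on an aromatic ring The surroundings of the change are the same in both pairs, so this is the same change, seen for the second time among these compounds.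

The step expected in this assay is a 1.2-fold higher number from compound 3 to compound 4 (0.08 log units; within the scatter), a small one, because the same change earlier gave a 1.2-fold higher number from compound 1 to compound 2 (0.08 log units; within the scatter). Two examples are a thin basis, and the core is different, so the range around the estimate is kept wide. For compound 4 the estimated value is 7500 nM, expected to fall between 3500 nM and 16000 nM.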

Compound 4, half-maximal inhibitory concentration: > 50000 nM
Compound 4 was reported as a limit (the forecaster's own chance of this, stated with the estimate: 10%); middle value at least 6.6-fold (0.82 log units) away from the limit.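

In this assay compound 4 gives > 50000 nM, which is a limit of the assay and not a number. Benzyl in place of 4-hydroxycyclohexyl on the oxygen gives an at least 7.9-fold higher number from compound 3 to compound 4 (0.89 log units; beyond the scatter), and this step does not match the one seen on the other core: the same change on two cores in this assay, a 1.2-fold higher number (0.08 log units; within the scatter) from compound 1 to compound 2 and an at least 7.9-fold higher number (0.89 log units; beyond the scatter) from compound 3 to compound 4, at least 6.6-fold (0.81 log units) apart, beyond the scatter of two such steps This shows that, in this series, the effect of the exchange on one core did not carry over to the other, so the pair of compound 1 and compound 2 was a poor guide to the pair of compound 3 and compound 4, but it does not show why the two cores differ, and the full size of the second step stays unknown since one end of it is a limit.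

With only one pair on each core, the compounds shown leave open which part of the difference between the two cores goes with the larger step. They also leave open how this core would respond to other groups on the same oxygen, such as a plain cyclohexyl without its hydroxyl, a short chain ending in an amine, or one ending in a carboxylic acid.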